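The source may report more compounds than this note shows. Statements on the series, on what has been measured and on what is new or still open speak of the compounds shown alone.

Working notes on the series.

Three compounds are measured in an assay on membranes from Cortex for displacement of a labelled ligand from Sigma non-opioid intracellular receptor 1 (Cavia porcellus), read by scintillation counting, with a stated time of 120 min; on this read-out higher numbers stand for weaker inhibition and lower numbers for stronger inhibition. Compound 1 `OC(Cc1ccccc1)CN1CCC(NCCSC(c2ccc(F)cc2)c2ccc(F)cc2)CC1` gives 309 nM. Compound 2 `[O-][S+](CCNC1CCN(CC(O)Cc2ccccc2)CC1)C(c1ccc(F)cc1)c1ccc(F)cc1` gives 351 nM. Compound 3 `O=C(c1ccccc1)N1CCC(NCCSC(c2ccc(F)cc2)c2ccc(F)cc2)CC1` gives 2.03 nM. Compound 1 and compound 2 share most of their structure but differ in more than one place; how their two cores differ is not broken down here, and their two values lie within the usual scatter of each other, so nothing is read into their order.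

Within the data shown here, the one change that is measured in a single step is benzoyl in place of 2-hydroxy-3-phenylpropyl on an amine nitrogen in a ring. It produced a 150-fold lower number from compound 1 to compound 3 (2.18 log units; beyond the scatter), a large step and well beyond the scatter.

Compound 4 `O=C(c1ccccc1)N1CCC(NCC[S+]([O-])C(c2ccc(F)cc2)c2ccc(F)cc2)CC1` is not yet measured. It differs from compound 2 by benzoyl in place of 2-hydroxy-3-phenylpropyl on an amine nitrogen in a ring, which is the same change as from compound 1 to compound 3, at the same place described in the same words. The change occurs twice in all among these compounds, and only one instance has a number. The expectation for compound 2 to compound 4 therefore rests on that single measured step: because compound 1 to compound 3 moved by a 150-fold lower number from compound 1 to compound 3 (2.18 log units; beyond the scatter) the step of a 120-fold lower number from compound 2 to compound 4 (2.07 log units; beyond the scatter) is expected, allowing for the possibility that a step of this size is not fully repeated against a different core. Starting from compound 2 at 351 nM, compound 4 is estimated at 3 nM, expected to fall between 1 nM and 12 nM in this assay.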

Compound 4, inhibition constant: 585 nM
Compound 4: the middle estimate sits 200-fold (2.29 log units) below what was measured; measured number outside the range, above it.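

In this assay, benzoyl in place of 2-hydroxy-3-phenylpropyl on an amine nitrogen in a ring gave a 1.7-fold higher number from compound 2 to compound 4 (0.22 log units; within the scatter), a step that stays within the scatter, so the large step seen on the core of compound 1 was not repeated on the core of compound 2. The two instances of the change therefore disagree, and the size of the step in this series depends on the core that carries it: the same change on two cores in this assay, a 150-fold lower number (2.18 log units; beyond the scatter) from compound 1 to compound 3 and a 1.7-fold higher number (0.22 log units; within the scatter) from compound 2 to compound 4, 250-fold (2.40 log units) apart, beyond the scatter of two such steps. What this does not show is which feature of the two cores accounts for the disagreement, or which of the two outcomes would hold on a further core, since two instances on two cores give a contrast and not a rule.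

The compounds shown leave open whether a different group on the same ring nitrogen, such as a benzyl or an acetyl group, would give a large step on one core and none on the other, as benzoyl does here. They also leave open how a sulfone in place of the sulfoxide of compound 2 and compound 4, or a longer chain between the sulfur and the ring, would alter the size of this step.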